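A few compounds are considered here, and "the series" means these few. Any claim that something is new, unique, unknown or untested is made for them only; others in the source may bear on it.

Four compounds that share one core are compared in a functional assay on KM12 cells (Homo sapiens) for inhibition, read by sulforhodamine B assay, with a stated time of 48 h; a lower number here means that less compound is tolerated, a higher number that more compound is tolerated. Compound 1 `COc1cc(-c2nn(-c3cccc(NC(=O)Nc4cc(C(F)(F)F)cc(C(F)(F)F)c4)c3)cc2-c2ccncc2)ccc1Cl` gives 3390 nM. Compound 2 `COc1cc(-c2nn(-c3cccc(NC(=O)Nc4ccc(Cl)c(Cl)c4)c3)cc2-c2ccncc2)ccc1Cl` gives 49500 nM; how the cores of compound 1 and compound 2 differ is not broken down here. Compound 3 `O=C(Nc1cccc(-n2cc(-c3ccncc3)c(-c3ccc(Cl)c(O)c3)n2)c1)Nc1ccc(Cl)c(Cl)c1` gives 26300 nM. Compound 3 arises from compound 2 by hydrogen in place of methyl on an oxygen on an aromatic ring, and that step is a 1.9-fold lower number from compound 2 to compound 3 (0.27 log units; within the scatter). Compound 4 `O=C(Nc1cccc(-n2cc(-c3ccncc3)c(-c3ccc(Cl)c(O)c3)n2)c1)Nc1cc(C(F)(F)F)cc(C(F)(F)F)c1` has not yet been measured in this assay; it arises from compound 1 by the same change, (hydrogen in place of methyl on an oxygen on an aromatic ring), made at the same place. The step is expected to be small for compound 4, a 1.4-fold lower number from compound 1 to compound 4 (0.13 log units; within the scatter), because the earlier step of a 1.9-fold lower number from compound 2 to compound 3 (0.27 log units; within the scatter) stayed within the scatter. In this assay compound 4 is estimated at 2500 nM, most likely between 1000 nM and 6500 nM.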

Compound 4, concentration lethal to 50% of the cells: 4060 nM
Compound 4: middle estimate off by 1.6-fold (0.21 log units), on the low side; low and high end bracket the measured number.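

In this assay, replacing methoxy with hydroxy on the 4-chloro-3-methoxyphenyl group gives a 1.2-fold higher number from compound 1 to compound 4 (0.08 log units; within the scatter). Set beside the earlier case, the same change behaves alike on the two cores shown: the same change on two cores in this assay, a 1.9-fold lower number (0.27 log units; within the scatter) from compound 2 to compound 3 and a 1.2-fold higher number (0.08 log units; within the scatter) from compound 1 to compound 4, 2.3-fold (0.35 log units) apart, within the scatter of two such steps. This suggests that, on these two cores, the swap leaves the number within the usual scatter, but two pairs do not establish a rule for the series and do not explain why the change has so little effect.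

The compounds shown leave open whether a longer chain on that oxygen, such as ethoxy, or an amine in place of the hydroxy would shift the number beyond the scatter. They also leave open how the same change would behave on a third core.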